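This account rests on a few compounds, and the source may have more. Where it says the series, first, only, none or still open, it means among the compounds named here.

Compound 1 `CC(=O)Oc1ccc2cc(-c3ccsc3)c(=O)oc2c1OC(C)=O` and compound 2 `CC(=O)Oc1ccc2cc(-c3cc(Br)cs3)c(=O)oc2c1OC(C)=O` share one core, and compound 3 `O=c1oc2c(O)cccc2cc1-c1ccsc1` and compound 4 `O=c1oc2c(O)cccc2cc1-c1cc(Br)cs1` another; the difference between the two cores is not broken down here. In an assay on CHO cells for displacement of a labelled ligand from adenosine receptor A1 (Homo sapiens) (a lower number here means a stronger inhibitor, a higher number a weaker inhibitor), compound 1 gives > 100000 nM, which is a limit of the assay. Compound 2 likewise gives only a limit, > 100000 nM. Among the compounds with values here, compound 3 gives 5920 nM in this assay, the only number among the three. The change 4-bromothiophen-2-yl in place of thiophen-3-yl on an aromatic carbon therefore produced a step that the two limits leave unreadable from compound 1 to compound 2, both values resting at the limit of > 100000 nM in this assay, at which 2 of the 3 values shown sit. The same change, (4-bromothiophen-2-yl in place of thiophen-3-yl on an aromatic carbon), is now made on the core of compound 3. Since the earlier step gives no readable size, the expectation for compound 4 rests on compound 3 alone at 5920 nM, and a step of a 1.0-fold higher number from compound 3 to compound 4 (0.01 log units; within the scatter) is expected. Compound 4 is estimated at 6000 nM, between 1500 nM and 25000 nM.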

Compound 4, inhibition constant: > 100000 nM
Compound 4 gave a limit, no number; the forecaster's own chance of this, stated with the estimate: 15%; middle value at least 16-fold (1.22 log units) from the limit.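

In this assay, going by these compounds, the change to 4-bromothiophen-2-yl on the core of compound 3 gave an at least 16-fold higher number from compound 3 to compound 4 (1.22 log units; beyond the scatter), a large step towards a weaker inhibitor whose full size stays unknown. Compound 4 gives > 100000 nM, which is a limit and not a number. The step on the core of compound 1 cannot be read, so the series does not show whether the change acts alike on both cores, only that the two bromothiophene compounds end at the same limit: the limit of > 100000 nM in this assay, at which 3 of the 4 values shown sit.

The compounds shown leave open whether the step comes from the bromine or from the change of thiophene attachment, as the two arrive together. A plain thiophen-2-yl or a chlorine in place of the bromine on the core of compound 3 would bear on this.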